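A few compounds are considered here, and "the series" means these few. Any claim that something is new, unique, unknown or untested is made for them only; others in the source may bear on it.

The series rests on a shared core, carried by compound 1 `CC(=O)N[C@H]1[C@@H](OCc2ccccc2)O[C@H](CO)[C@@H](O)[C@@H]1O`, compound 2 `CC(=O)N[C@H]1[C@@H](OCCc2ccccc2)O[C@H](CO)[C@@H](O)[C@@H]1O` and compound 3 `CC(=O)N[C@H]1[C@@H](OCCCCc2ccccc2)O[C@H](CO)[C@@H](O)[C@@H]1O`. In a functional assay on A-375 cells (Homo sapiens), read by thymidine incorporation (a higher number here means a weaker inhibitor, a lower number a stronger inhibitor), compound 1 returns only a limit of the assay, > 50 uM. Compound 2 likewise returns only a limit in this assay, > 50 uM. Compound 3 too reaches only a limit in this assay, > 50 uM. Compound 2 thus stands at the same limit as the two compounds around it, and the two steps joining them, a step that the two limits leave unreadable from compound 1 to compound 2 and a step that the two limits leave unreadable from compound 2 to compound 3, are left without a readable size because of the limit of > 50 uM in this assay, at which 3 of the 3 values shown sit. Compound 4 `C=CCCC(=O)N[C@H]1[C@@H](OCCc2ccccc2)O[C@H](CO)[C@@H](O)[C@@H]1O` departs from compound 2 at the other end of the molecule: allyl in place of hydrogen on a saturated chain carbon bound to a carbonyl carbon. Going by the values given here, none of the measured steps touches this place; each of them only alters the chain that carries the phenyl. Among the compounds with values here, nothing measured so far bears on the change, and three values sitting at the limit give no foothold for a direction. Compound 4 is therefore expected to stay near the limit as well, with an estimated step that the limit leaves unreadable from compound 2 to compound 4 of no readable size beyond the scatter. Compound 4 is accordingly estimated at 60 uM, within a range from 15 uM to 200 uM.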

Compound 4, concentration for 50% inhibition: > 50 uM
Compound 4 gave a limit, no number (the forecaster's own chance of this, stated with the estimate: 75%); the middle value does not contradict the limit.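

Compound 4 returns only a limit, as compound 2 does, so no size can be read for the change between compound 2 and compound 4, because neither gives a number: the limit of > 50 uM in this assay, at which 4 of the 4 values shown sit.

The compounds shown leave open whether any change to the chain carrying the phenyl or to the acetamido group gives a measurable value in this assay.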